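The source may report more compounds than this note shows. Statements on the series, on what has been measured and on what is new or still open speak of the compounds shown alone.

Measured so far in a physicochemical assay for solubility, with a stated time of 4 h, at pH 7.4; a higher number here means a more soluble compound, a lower number a less soluble compound
compound 1 `CC(=O)CCc1cc(C)c(Oc2cc(Nc3ccc(C#N)cc3)c(N)cc2C(F)(F)F)c(C)c1` gives 0.16 ug/mL
compound 2 `Cc1cc(/C=C/C#N)cc(C)c1Oc1cc(Nc2ccc(C#N)cc2)c(N)cc1[N+](=O)[O-]` gives 0.29 ug/mL
compound 3 `Cc1cc(C#N)cc(C)c1Oc1cc(Nc2ccc(C#N)cc2)c(N)cc1C(F)(F)F` gives 0.26 ug/mL

In this assay compound 2 lies within the scatter of both compound 1 and compound 3, so these three values cannot be ranked.

Compound 4 `Cc1cc(/C=C/C#N)cc(C)c1Oc1cc(Nc2ccc(C#N)cc2)c(N)cc1CO` departs from compound 2 by one exchange, hydroxymethyl in place of nitro on an aromatic carbon with its result still to come.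

Among the compounds with values here, only one measured step is available, cyano in place of 2-acetylethyl on an aromatic carbon, and it reads a 1.6-fold higher number from compound 1 to compound 3 (0.21 log units; within the scatter) as its size. That step involves neither nitro nor hydroxymethyl, so it offers only a loose guide to the size of this exchange.

Within the data shown here, the expectation starts from compound 2 at 0.29 ug/mL and leans slightly upward, although no measured step establishes that direction. The expected step is a 1.7-fold higher number from compound 2 to compound 4 (0.24 log units; within the scatter) and no move beyond the scatter is anticipated.

For compound 4 the estimate is 0.5 ug/mL with an expected range from 0.18 ug/mL to 1.5 ug/mL as its bounds.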

Compound 4, solubility: 3.23 ug/mL
Compound 4: the middle estimate sits 6.5-fold (0.81 log units) below what was measured; measured number above the stated range.
By their numbers in this assay, from the lowest: compounds 1, 3 and 2 (each within the scatter of the next); then compound 4.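

In this assay, within the data shown here, hydroxymethyl in place of nitro, on the aromatic carbon para to the (4-cyanophenyl)amino group, gives an 11-fold higher number from compound 2 to compound 4 (1.05 log units; beyond the scatter), while the only other step available, a 1.6-fold higher number from compound 1 to compound 3 (0.21 log units; within the scatter), stays within the scatter. Among these compounds, this place on the core is therefore one where a single exchange can move the number well beyond the scatter, which the earlier compounds did not show. The exchange brings in a hydrogen-bond donor that nitro lacks, but nothing available on this pair explains the size of the step.

Open, from the compounds shown here alone, is whether an amine, a carboxylic acid or a longer chain ending in hydroxyl at this place would give a number near that of compound 4. Also open, going by these compounds, is whether hydroxymethyl in place of trifluoromethyl on the core of compound 3 would give a step of similar size.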